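This account rests on a few compounds, and the source may have more. Where it says the series, first, only, none or still open, it means among the compounds named here.

Among the measured compounds shown here, in an assay on isolated protein for inhibition of Aromatase (Homo sapiens), read by fluorescence, tested at 1 uM (on this read-out higher numbers stand for more inhibition at the one concentration tested (going by the name of the read-out) and lower numbers for less inhibition), compound 3 `N#Cc1ccc(Oc2cccnc2)cc1NC1CCCCC1` gives 33%, the lowest of the three numbers measured so far. Compound 1 `N#Cc1ccc(Oc2cccnc2)cc1NCc1ccccc1` gives 58% and compound 2 `N#Cc1ccc(Oc2cccnc2)cc1Oc1ccccc1` gives 78% in this assay, both beyond the scatter above compound 3. The two steps leading into compound 3 are a number 25 percentage points lower from compound 1 to compound 3 (beyond the scatter), a modest fall for cyclohexyl in place of benzyl on a nitrogen on an aromatic ring, and a number 45 percentage points lower from compound 2 to compound 3 (beyond the scatter), a large fall for cyclohexylamino in place of phenoxy on an aromatic carbon. In both, a six-membered non-aromatic ring of carbon only at this place goes with less inhibition than the group it replaced. Compound 4 `CN1CCN(c2cc(Oc3cccnc3)ccc2C#N)CC1` carries 4-methylpiperazin-1-yl in place of cyclohexylamino on an aromatic carbon. For the measured compounds named here, no measured step covers a six-membered non-aromatic ring with 2 hetero atoms at this place, and the loss of the hydrogen-bond donor is likewise untested. The leaving and entering groups are both six-membered non-aromatic rings, so the expected step is small, a number 5 percentage points lower from compound 3 to compound 4 (within the scatter), not beyond the scatter. Compound 4 is therefore expected to give 28% in this assay, within 10% to 50%.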

Compound 4, a percentage reported as inhibition, at one concentration (the size of the read-out at that concentration, not a potency): 8%
Compound 4: the middle estimate sits 20 percentage points above what was measured, outside the stated range (below it).
By their numbers in this assay, from the lowest: compound 4; then compound 3; then compound 1; then compound 2.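

At this place, on an aromatic carbon ortho to a cyano group, one six-membered non-aromatic ring cannot simply stand in for another: in this assay the change to 4-methylpiperazin-1-yl gives a number 25 percentage points lower from compound 3 to compound 4 (beyond the scatter), so the ring type or the amine link matters here, not ring size alone. Replacing phenoxy with the same group gives a number 70 percentage points lower from compound 2 to compound 4 (beyond the scatter), a wider step than the fall seen with cyclohexylamino in place of phenoxy. No measurement on hand explains either fall.

Compound 4 loses the hydrogen-bond donor and gains a second ring nitrogen in one step, and the compounds shown do not separate these two changes. A piperidin-1-yl group at this place would part them, and a morpholin-4-yl group would show whether oxygen in the ring reads the same as the methylated nitrogen.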